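The source may hold more compounds than are shown below. What is called first, only, known or untested is meant among the compounds shown, and "the series" means these compounds.

Compound 1 `O=C(N/N=C/c1ccc(F)cc1)c1cccnc1Nc1cccc(C(F)(F)F)c1` was tested in a functional assay on the whole organism (strain Wistar) for inhibition, with Rattus norvegicus as the target, read by paw edema, with a stated time of 2 h, at a dose of 10 mg/kg by the intraperitoneal route (on this read-out higher numbers stand for more inhibition at the one dose given (going by the name of the read-out) and lower numbers for less inhibition), where compound 1 gives 41.2%. Two relatives differ from it only in the aryl group on the carbon with a double bond to nitrogen. Compound 2 `COc1ccc(/C=N/NC(=O)c2cccnc2Nc2cccc(C(F)(F)F)c2)c(OC)c1` gives 44.7% in this assay, and compound 3 `COc1ccc(/C=N/NC(=O)c2cccnc2Nc2cccc(C(F)(F)F)c2)cc1OC` gives 49%. Compound 1 carries the smallest of the three figures, but the steps of a number 3.5 percentage points higher from compound 1 to compound 2 (within the scatter) and a number 7.8 percentage points higher from compound 1 to compound 3 (within the scatter) both fall within the scatter, as does the step of a number 4.3 percentage points higher from compound 2 to compound 3 (within the scatter), so the three compounds cannot be told apart on these numbers.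

Compound 4 `O=C(N/N=C/c1ccncc1)c1cccnc1Nc1cccc(C(F)(F)F)c1` is the next variation at the same position: pyridin-4-yl in place of 4-fluorophenyl on a carbon with a double bond to nitrogen. Within the data shown here, no measured step introduces pyridin-4-yl, so the closest guidance comes from the three swaps of this aryl group already measured, all of which moved the read-out by amounts inside the scatter. A further swap at the same carbon is therefore expected to behave alike, with no step beyond the scatter in either direction. The expected step of a number 1.8 percentage points higher from compound 1 to compound 4 (within the scatter) is accordingly small. Compound 4 is estimated to give 43% in this assay, with a range from 30% to 56%.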

Compound 4, a percentage reported as inhibition, in the whole organism at one dose (the size of the read-out at that dose, not a potency): 65.2%
Compound 4: middle estimate off by 22.2 percentage points, on the low side; measured number outside the range, above it.
By their numbers in this assay, from the lowest: compounds 1, 2 and 3 (each within the scatter of the next); then compound 4.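

In this assay, the aryl group on the carbon with a double bond to nitrogen turns out to matter more than the earlier swaps suggested: those stayed inside the scatter, whereas pyridin-4-yl stands clear of all three relatives, with a number 24 percentage points higher from compound 1 to compound 4 (beyond the scatter), a number 20.5 percentage points higher from compound 2 to compound 4 (beyond the scatter) and a number 16.2 percentage points higher from compound 3 to compound 4 (beyond the scatter). Unlike the 4-fluorophenyl it replaces, pyridin-4-yl has a hetero atom in its ring and a hydrogen-bond acceptor, and among these four compounds it is the only aryl group with a hetero atom in the ring, although a single compound cannot show that this difference is what counts. Nothing available here bears on why this swap gives the larger number.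

As far as these compounds go, it remains open whether the step belongs to pyridin-4-yl alone or would also appear with pyridin-3-yl, with a furan ring, or with a phenyl ring carrying an amine or a carboxylic acid. From the compounds shown here alone, all four compounds also share the same core, so it is unknown whether the step would hold if a nitrile stood in place of the trifluoromethyl group.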